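Aryl Swap on a Pyrazole Carboxylic Acid Core

The source may report more compounds than this note shows. Statements on the series, on what has been measured and on what is new or still open speak of the compounds shown alone.

Measured so far:
Compound 1, `Cc1cc(Cl)cc(-c2c(C)nn(-c3nc(-c4ccc(Cl)c(Cl)c4)c(SC(C)C)s3)c2C(=O)O)c1`, gives 663 nM.
Compound 2, `Cc1nn(-c2nc(-c3ccc(Cl)c(Cl)c3)c(SC(C)C)s2)c(C(=O)O)c1-c1cccc(C(F)(F)F)c1`, gives 22000 nM.

For the measured compounds named here, in a functional assay on BJAB cells (Homo sapiens) for antiproliferative activity, with a stated time of 4 days (a higher number here means that more compound is needed for the effect, a lower number that less compound is needed), compound 2 stands at the higher of the two numbers; the only measured step leading to it, a 33-fold higher number from compound 1 to compound 2 (1.52 log units; beyond the scatter), came from the aryl exchange of 3-(trifluoromethyl)phenyl for 3-chloro-5-methylphenyl on the shared core. Compound 3, `Cc1nn(-c2nc(-c3ccc(Cl)c(Cl)c3)c(SC(C)C)s2)c(C(=O)O)c1-c1cnccn1`, has not yet been measured. Its difference from compound 2 is pyrazin-2-yl in place of 3-(trifluoromethyl)phenyl on an aromatic carbon. Going by the values given here, no measured step covers a pyrazinyl ring at this position; the single related step, from compound 1 to compound 2, shows that this aryl position alone can shift the number strongly in either direction. The size and direction of the next step are therefore open, and compound 3 is expected to fall near compound 2, with a wide range, as a 1.8-fold higher number from compound 2 to compound 3 (0.26 log units; within the scatter). The estimate for compound 3 is 40000 nM, between 8000 nM and 200000 nM.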

Compound 3, half-maximal effective concentration: 14000 nM
Beside the measured number, compound 3's estimate is 2.9-fold (0.46 log units) above it, and the stated range covers the measured number.
By their numbers in this assay, from the lowest: compound 1; then compounds 3 and 2 (each within the scatter of the next).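

In this assay, the pyrazin-2-yl ring and the 3-(trifluoromethyl)phenyl ring cannot be told apart at this position, with a 1.6-fold lower number from compound 2 to compound 3 (0.20 log units; within the scatter) on exchanging one for the other. The large distance from compound 1 returns with this second replacement, as a 21-fold higher number from compound 1 to compound 3 (1.32 log units; beyond the scatter) shows, so it is not particular to the trifluoromethyl-bearing ring: both replacements of 3-chloro-5-methylphenyl end far from compound 1, although one brings ring nitrogens and the other a carbon-only ring. No supporting evidence bears on this result.

The compounds shown leave open whether the chloro group or the methyl group of compound 1 carries its lower number, since no phenyl ring with only one of them appears. On these data alone, an unsubstituted phenyl ring or a pyridinyl ring here also remains open.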